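Extending the methyl group on compound 3 to a butyl chain

The source may hold more compounds than are shown below. What is called first, only, known or untested is meant among the compounds shown, and "the series" means these compounds.

The measured compounds and their values:
compound 1 `OCc1ccc(-c2nn(Cc3ccccc3F)c3ncccc23)o1` — 1700 nM; 1700 nM (2 entries)
compound 2 `Fc1ccccc1Cn1nc(C2=NCCN2)c2cccnc21` — 3200 nM
compound 3 `Cc1cnc(-c2nn(Cc3ccccc3F)c3ncccc23)nc1N` — 675000 nM

Of the compounds shown here, three sharing the same core have been measured in a functional assay (aorta) with Oryctolagus cuniculus as the target; a higher number here means a weaker inhibitor, a lower number a stronger inhibitor. Compound 1 gives 1700 nM; 1700 nM (2 entries) and compound 2 gives 3200 nM in this assay. Compound 3 stands highest of the two single numbers in this assay, with 675000 nM; its nearest neighbour is compound 2, and the step of a 210-fold higher number from compound 2 to compound 3 (2.32 log units; beyond the scatter) lies far beyond the scatter.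

Compound 4 `CCCCc1cnc(-c2nn(Cc3ccccc3F)c3ncccc23)nc1N` is the next compound. It differs from compound 3 by propyl in place of hydrogen on a saturated chain carbon bound to an aromatic carbon. Among the compounds with values here, no measured step in this set concerns an alkyl chain on this part of the core; the only step on record, from compound 2 to compound 3, exchanges the whole ring attached to the core and therefore does not bear directly on a chain extension. With nothing in the data to point either way, no step beyond the scatter is expected in this assay, and the estimated change is a 1.4-fold lower number from compound 3 to compound 4 (0.13 log units; within the scatter). The expected value for compound 4 in this assay is therefore 500000 nM, with a range from 150000 nM to 1500000 nM.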

Compound 4, half-maximal inhibitory concentration: 218000 nM
Compound 4: middle estimate off by 2.3-fold (0.36 log units), on the high side; the measured number falls inside the stated range.
By their numbers in this assay, from the lowest: compound 2; then compound 4; then compound 3.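

In this assay, within the data shown here, the exchange of hydrogen for propyl on a saturated chain carbon bound to an aromatic carbon, which can equally be read as methyl to butyl, gives a 3.1-fold lower number from compound 3 to compound 4 (0.49 log units; beyond the scatter) and so provides the first reading at this position. Among these compounds, the only earlier step, a 210-fold higher number from compound 2 to compound 3 (2.32 log units; beyond the scatter) in the same assay, exchanged a whole ring and said nothing about this chain, whereas the new step keeps that ring in place and shows that changing the chain alone moves the number beyond the scatter, though only modestly and far less than the ring exchange did. No measurement shown here explains this shift, and its cause remains unknown.

A single step with two chain lengths cannot show whether the number falls steadily with each added carbon, or whether a longer chain such as hexyl or a branched one such as isobutyl would continue the change. It also leaves open how a terminal amine or carboxylic acid on the butyl chain would compare with the plain chain in this assay.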